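Cytotoxicity of cyclic sulfonamide analogues: swapping an aryl for propargyl

The source may hold more compounds than are shown below. What is called first, only, known or untested is meant among the compounds shown, and "the series" means these compounds.

Measured so far:
compound 1 `O=C1c2ccccc2N(Cc2ccc(C(F)(F)F)cc2)S(=O)(=O)N1Cc1ccc(C(F)(F)F)cc1`, 48000 nM
compound 2 `O=C1c2ccccc2N(Cc2ccc(C(F)(F)F)cc2)S(=O)(=O)N1Cc1ccccc1`, 56000 nM
compound 3 `O=C1c2ccccc2N(Cc2ccccc2Cl)S(=O)(=O)N1Cc1ccccc1Cl`, 56000 nM

Each of these was tested in a functional assay on MRC5 cells (Homo sapiens); a lower number here means that less compound is tolerated, a higher number that more compound is tolerated. Compound 2 stands level with compound 3 at the digits printed, and together they give the highest numbers of the three; compound 1 sits nearest below, and the gap between compound 1 and compound 2 is within the scatter. All three compounds are therefore tolerated to a similar degree.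

Compound 4 `C#CCCN1c2ccccc2C(=O)N(Cc2ccccc2)S1(=O)=O` has not yet been measured. It differs from compound 2 in one place:
propargyl in place of 4-(trifluoromethyl)phenyl on a saturated chain carbon bound to a sulfonamide nitrogen in a ring

Going by the values given here, only one step among the measured compounds is known in one place, a 1.2-fold higher number from compound 1 to compound 2 (0.07 log units; within the scatter), and it concerns a trifluoromethyl on the other side of the shared core, not the position changed here. Among the compounds with values here, no measured step removes an aromatic ring from this position, so the data give little guidance. Since compound 2 shows 56000 nM and all three measured compounds lie close together, compound 4 is expected to stay in the same range, with a step of a 1.1-fold higher number from compound 2 to compound 4 (0.03 log units; within the scatter). The estimate for compound 4 is 60000 nM, with a range from 30000 nM to 120000 nM.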

Compound 4, half-maximal cytotoxic concentration: 77000 nM
The estimate for compound 4 lay 1.3-fold (0.11 log units) below the measured number; low and high end bracket the measured number.
By their numbers in this assay, from the lowest: compounds 1, 2, 3 and 4 (each within the scatter of the next).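

In this assay the swap gives a 1.4-fold higher number from compound 2 to compound 4 (0.14 log units; within the scatter) and so leaves the number within the usual scatter, even though the change at this place is large. Going by these compounds alone, all the earlier compounds carried an aromatic ring here, whereas compound 4 shows that 4-(trifluoromethyl)phenyl, with 10 heavy atoms and one ring, can give way to propargyl, with 3 heavy atoms and no ring, and the compound is still tolerated to a similar degree. No measurement at hand explains why the number stays so close. The compounds shown leave open whether this place stays just as undemanding with an amine, a carboxylic acid or a longer chain on it. They also leave open whether propargyl on the other side of the shared core would behave the same way.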